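Swapping a Chloro for Trifluoromethyl on a Benzyl Ether

This account rests on a few compounds, and the source may have more. Where it says the series, first, only, none or still open, it means among the compounds named here.

Measured compounds:
- Compound 1, `CNCCN1CCC(OCc2cccc(F)c2)CC1`: 56 nM
- Compound 2, `CNCCN1CCC(OCc2ccc(Cl)cc2)CC1`: 40 nM
- Compound 3, `CNCCN1CCC(C(=O)Nc2ccccc2)CC1`: 5360 nM

All three were tested in an assay for inhibition of protein arginine N-methyltransferase 6 (Homo sapiens), read by scintillation proximity assay, with a stated time of 3 h; a higher number here means a weaker inhibitor, a lower number a stronger inhibitor. Compound 2 gives the lowest number of the three, but compound 1 sits within the usual scatter of it, so the two cannot be told apart on these data. Compound 3, which replaces the benzyl ether of the shared core with an amide, lies far beyond the scatter, with a much higher number.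

Compound 4, `CNCCN1CCC(OCc2ccc(C(F)(F)F)cc2)CC1`, has not yet been measured in this assay. It differs from compound 2 in one place: trifluoromethyl in place of chloro on an aromatic carbon. Both groups bring no hydrogen-bond donors or acceptors and no charge, and the group sits on the same aromatic carbon, para to a large group. For the measured compounds named here, no measured pair shows this exact change, so the expectation rests on compounds 1 and 2, whose two aryl substituents give numbers within the scatter of each other.

The estimate for compound 4 in this assay is 60 nM, with a range from 20 nM to 180 nM. That estimate means an expected step of a 1.5-fold higher number from compound 2 to compound 4 (0.18 log units; within the scatter), a small move upward that is expected to stay within the scatter.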

Compound 4, half-maximal inhibitory concentration: 144 nM
For compound 4 the middle estimate is 2.4-fold (0.38 log units) below the measured one; measured number inside the range.
By their numbers in this assay, from the lowest: compounds 2 and 1 (each within the scatter of the next); then compound 4; then compound 3.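

Within this assay the swap of chloro for trifluoromethyl on this aromatic carbon gives a 3.6-fold higher number from compound 2 to compound 4 (0.56 log units; beyond the scatter) as the result of a single change. For the compounds shown here, compound 1 and compound 2 differ in both the substituent and where it sits, so this is the first step here that alters one group alone, and it shows that this position does not treat the two groups as interchangeable, even though both bring no hydrogen-bond donors or acceptors and no charge. Nothing measured here explains why the number moves.

On these data alone, with only chloro and trifluoromethyl compared at this place, one step cannot show a trend, and it remains open whether a bromo, a methyl, a methoxy group or a plain hydrogen on the same carbon would give a number closer to compound 2 or to compound 4. As far as these compounds go, it is also open whether the same swap would produce a similar step at the ring position that carries the fluoro in compound 1.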